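The source may hold more compounds than are shown below. What is called first, only, known or untested is meant among the compounds shown, and "the series" means these compounds.

Working notes on the series.

Going by the values given here, compound 1 `COc1cc(C(=O)c2sc(-c3ccc([N+](=O)[O-])cc3)cc2N)cc(OC)c1OC` gives 99 nM in a functional assay on CCRF-CEM cells (Homo sapiens) for antiproliferative activity (on this read-out higher numbers stand for weaker inhibition and lower numbers for stronger inhibition), the lowest of the two numbers so far. Its nearest neighbour is compound 2 `COc1cc(C(=O)c2sc(-c3ccc(I)cc3)cc2N)cc(OC)c1OC`, which gives 150 nM in this assay; the step of a 1.5-fold higher number from compound 1 to compound 2 (0.18 log units; within the scatter) stays within the scatter, so the two values are not ordered.

Compound 3 `CCOc1ccc(-c2cc(N)c(C(=O)c3cc(OC)c(OC)c(OC)c3)s2)cc1` differs from compound 1 by a single change: ethoxy in place of nitro on an aromatic carbon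

Among the compounds with values here, the only measured step that bears on this change is the one from compound 1 to compound 2, a swap of the group on the same aromatic carbon, and it was within the scatter. Within the data shown here, with one step on record and no ethoxy analogue measured, no movement beyond the scatter in this assay is expected for compound 3, in either direction. The estimated step is a 1.5-fold higher number from compound 1 to compound 3 (0.18 log units; within the scatter). Compound 3 is therefore expected to give about 150 nM in this assay, with a range from 50 nM to 450 nM.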

Compound 3, half-maximal inhibitory concentration: 270 nM
Compound 3: middle estimate off by 1.8-fold (0.26 log units), on the low side; the measured number falls inside the stated range.
By their numbers in this assay, from the lowest: compounds 1, 2 and 3 (each within the scatter of the next, the first and the last beyond it).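

In this assay, going by these compounds alone, the exchange of nitro for ethoxy, on an aromatic carbon para to a large group, gives a 2.7-fold higher number from compound 1 to compound 3 (0.44 log units; beyond the scatter) as the first step at this position that lies beyond the scatter, and it is a modest one. The other new step, a 1.8-fold higher number from compound 2 to compound 3 (0.26 log units; within the scatter), stays within the scatter, so iodo and ethoxy are not ordered and only the nitro and ethoxy pair separates. No evidence on hand accounts for this difference.

Going by these compounds, the series at this carbon rests on nitro, iodo and ethoxy alone, so what an amine or a carboxylic acid would give here stays open. Also open, on these data alone, is whether a longer chain than ethoxy would stay close to compound 3 or move further from compound 1.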